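A few compounds are considered here, and "the series" means these few. Any claim that something is new, unique, unknown or untested is made for them only; others in the source may bear on it.

Measured so far in a functional assay on the whole organism for inhibition, with Rattus norvegicus as the target, read by cytopathic effect and paw edema, at a dose of 100 mg/kg by the oral route; on this read-out higher numbers stand for more inhibition at the one dose given (going by the name of the read-out) and lower numbers for less inhibition:
compound 1 `O=C(Nc1ccccn1)c1c(O)c2cccnc2n(-c2ccccc2)c1=O` gives 14.6%
compound 2 `CCCCNC(=O)c1c(O)c2cccnc2n(-c2ccccc2)c1=O` gives 20.4%
compound 3 `O=C(Nc1ccc(Cl)cc1)c1c(O)c2cccnc2n(-c2ccccc2)c1=O` gives 2.5%

Compound 3 stands lowest of the three. Its nearest neighbour is compound 1, the gap being a number 12.1 percentage points lower from compound 1 to compound 3 (beyond the scatter); the furthest is compound 2, with a number 17.9 percentage points lower from compound 2 to compound 3 (beyond the scatter). Between the two others the step of a number 5.8 percentage points higher from compound 1 to compound 2 (within the scatter) is within the scatter.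

The unmeasured compound 4 `COc1ccccc1NC(=O)c1c(O)c2cccnc2n(-c2ccccc2)c1=O` differs from compound 3 by 2-methoxyphenyl in place of 4-chlorophenyl on an amide-type nitrogen. Going by the values given here, the steps that bear on this are the two leading into compound 3: each replaced pyridin-2-yl or butyl on the amide-type nitrogen by 4-chlorophenyl and gave a modest drop. Among the compounds with values here, the present change keeps a six-membered aromatic ring of carbon only on that nitrogen and swaps 4-chlorophenyl for 2-methoxyphenyl; no measured step shows what 2-methoxyphenyl does here. For compound 4 a number close to that of compound 3 is therefore expected, with the step of a number 5.5 percentage points higher from compound 3 to compound 4 (within the scatter) estimated as a slight rise that need not exceed the scatter. Compound 4 is estimated at 8%, within 0% to 22%.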

Compound 4, a percentage reported as inhibition, in the whole organism at one dose (the size of the read-out at that dose, not a potency): -10.1%
Compound 4: the middle estimate sits 18.1 percentage points above what was measured, outside the stated range (below it).
By their numbers in this assay, from the lowest: compound 4; then compound 3; then compounds 1 and 2 (each within the scatter of the next).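

In this assay, two groups on the amide-type nitrogen that each hold one six-membered aromatic ring of carbon only need not read alike: a number 12.6 percentage points lower from compound 3 to compound 4 (beyond the scatter) and lies beyond the scatter, so that ring alone does not set the number. Compound 4 at -10.1% gives the only negative number among the compounds shown, and the steps of a number 30.5 percentage points lower from compound 2 to compound 4 (beyond the scatter) and a number 24.7 percentage points lower from compound 1 to compound 4 (beyond the scatter) are the widest seen at this position. Nothing measured on hand accounts for the effect of 2-methoxyphenyl here.

Still open, on these data alone, is where plain phenyl on this nitrogen would fall relative to compound 3 and compound 4. Also open, as far as these compounds go, is whether a chain longer than butyl would read close to compound 2 or move away from it.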